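The source may report more compounds than this note shows. Statements on the series, on what has been measured and on what is new or still open speak of the compounds shown alone.

Measured compounds:
- compound 1, `O=c1c2cnn(-c3ccc(F)cc3)c2ncn1CC1(O)CCN(Cc2cccnc2)CC1` — "not determined" (no result reported)
- compound 2, `O=c1c2cnn(-c3ccc(F)cc3)c2ncn1CC1(O)CCN(Cc2ccccc2Br)CC1` — 3100 nM
- compound 3, `O=c1c2cnn(-c3ccc(F)cc3)c2ncn1CC1(O)CCN(Cc2cc(F)cc(F)c2)CC1` — "not determined" (no result reported)

All three share one core and differ only in the group attached to the saturated chain carbon bound to the amine nitrogen in the ring. The read-out is an assay on Sf21 cells for inhibition of ubiquitin carboxyl-terminal hydrolase 7 (Homo sapiens), read by spectrophotometry, with stated times of 30 min and 2 h; a higher number here means a weaker inhibitor, a lower number a stronger inhibitor. For the measured compounds named here, compound 1 stands without a single number in this assay; the same holds for compound 3, so the only number available comes from compound 2, which gives 3100 nM in this assay.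

Compound 4, `O=c1c2cnn(-c3ccc(F)cc3)c2ncn1CC1(O)CCN(Cc2ccc(Br)cc2Cl)CC1`, is the next compound. Its change from compound 1 is 4-bromo-2-chlorophenyl in place of pyridin-3-yl on a saturated chain carbon bound to an amine nitrogen in a ring. Going by the values given here, no measured pair shows what such a change does to this assay, and since compound 1 itself has no number, no direction for the step can be stated; a step of any size or none beyond the scatter is possible.

What can be said rests on compound 2 alone. Compound 4 is expected to land near 3000 nM, within roughly 800 nM to 12000 nM, because compound 2, which also carries a halogen-bearing benzyl group on the saturated chain carbon bound to the amine nitrogen in the ring, gives 3100 nM.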

Compound 4, half-maximal inhibitory concentration: 1900 nM
The estimate for compound 4 lay 1.6-fold (0.20 log units) above the measured number; the measured number falls inside the stated range.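

For the compounds shown here, putting 4-bromo-2-chlorophenyl in place of 2-bromophenyl on a saturated chain carbon bound to an amine nitrogen in a ring gives the first step that can be read at this position in this assay and that step is a 1.6-fold lower number from compound 2 to compound 4 (0.21 log units; within the scatter) so the two compounds cannot be told apart by this read-out. For this one pair, then, a different arrangement of halogens on the aromatic ring leaves the number within the usual scatter of repeated measurements, while steps involving compound 1 or compound 3 cannot be read, as neither has a single number. No measurement shown offers an explanation for this result.

From the compounds shown here alone, it remains open whether a benzyl group without any halogen, or one carrying a methoxy group, an amine or a carboxylic acid, would shift the number beyond the scatter at this position. The shared core stays the same in every compound shown, so these compounds also leave open what a change there, or a longer chain in place of the single carbon that links the aromatic ring to the amine nitrogen, would do.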